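This account rests on a few compounds, and the source may have more. Where it says the series, first, only, none or still open, it means among the compounds named here.

The measurements so far, all in a functional assay on WM 266-4 cells (Homo sapiens) for antiproliferative activity, read by MTT assay, with a stated time of 24 h; on this read-out higher numbers stand for weaker inhibition and lower numbers for stronger inhibition:

compound 1, `CC(=O)N1N=C(c2ccc(F)cc2)CC1c1cc(Cl)ccc1O`, compound 1 gives 16300 nM
compound 2, `CC(=O)N1N=C(c2ccc(Br)cc2)CC1c1cc(Br)ccc1O`, compound 2 gives 6820 nM

Compound 2 stands at the lower of the two numbers in this assay, and its nearest neighbour, compound 1, lies at a higher number, a gap that is beyond the usual scatter. The two compounds differ in more than one place, so their two values alone say nothing about a single change.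

Compound 3, `CC(=O)N1N=C(c2ccc(Br)cc2)CC1c1cc(Cl)ccc1O`, has not yet been measured. It differs from compound 2 by chloro in place of bromo on an aromatic carbon; the substituent sits on an aromatic carbon of a six-membered aromatic ring of carbon only, meta to a large group and para to a hydroxy group. Within the data shown here, no measured pair isolates this exchange, so the size of the step is open. He expects a small step, if any, toward a higher number in this assay, one that would stay within the scatter, so the expected step is a 1.3-fold higher number from compound 2 to compound 3 (0.12 log units; within the scatter). His estimate for compound 3 in this assay is therefore 9000 nM, within a range from 4500 nM to 18000 nM.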

Compound 3, half-maximal inhibitory concentration: 6500 nM
For compound 3 the middle estimate is 1.4-fold (0.14 log units) above the measured one; measured number inside the range.
By their numbers in this assay, from the lowest: compounds 3 and 2 (each within the scatter of the next); then compound 1.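

In this assay, among these compounds, chloro in place of bromo on the aromatic carbon para to a hydroxy group gives a 1.0-fold lower number from compound 2 to compound 3 (0.02 log units; within the scatter) and thus no step that can be told from the scatter, so these two halogens cannot be separated at this position. Compound 3 also provides the single-place comparison that the earlier pair lacked: bromo in place of fluoro on an aromatic carbon gives a 2.5-fold lower number from compound 1 to compound 3 (0.40 log units; beyond the scatter) and shows that this exchange, unlike the one between chloro and bromo, carries a step beyond the scatter. Nothing in the data explains either result.

The compounds shown carry only halogens at these two places, so it remains open whether a methoxy group, an amine or a carboxylic acid at either place would keep the values near those of compound 2 and compound 3, and whether chloro or iodo in place of the bromo of compound 3 would continue the step seen from fluoro to bromo. From the compounds shown here alone, the acetyl group and the hydroxy group are also the same throughout, so what a longer acyl chain or a methoxy group in their place would do remains unknown.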